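Methylsulfanyl in Place of Chloro: What to Expect

The source may hold more compounds than are shown below. What is called first, only, known or untested is meant among the compounds shown, and "the series" means these compounds.

Compound 1 `Cn1c(=O)c(=O)n(C2CCCC2)c2nc(N/N=C/c3ccc(Cl)cc3)ncc21`: 8420 nM
Compound 2 `Cn1c(=O)c(=O)n(C2CCCC2)c2nc(N/N=C/c3cccc(Cl)c3Cl)ncc21`: 17200 nM
Compound 3 `Cn1c(=O)c(=O)n(C2CCCC2)c2nc(N/N=C/c3cc([N+](=O)[O-])ccc3Cl)ncc21`: 9260 nM

In a functional assay on PC-3 cells (Homo sapiens) for antiproliferative activity, read by MTT assay (on this read-out higher numbers stand for weaker inhibition and lower numbers for stronger inhibition), compound 1 gives the lowest of the three numbers shown. Compound 3 sits within the scatter of it a 1.1-fold higher number from compound 1 to compound 3 (0.04 log units; within the scatter), while compound 2 lies beyond it a 2.0-fold higher number from compound 1 to compound 2 (0.31 log units; beyond the scatter), a modest step. Compound 4 `CSc1ccc(/C=N/Nc2ncc3c(n2)n(C2CCCC2)c(=O)c(=O)n3C)cc1` differs from compound 1 by methylsulfanyl in place of chloro on an aromatic carbon; read one bond further out, 4-chlorophenyl becomes 4-(methylsulfanyl)phenyl. Among the compounds with values here, no measured step changes that group; the two steps seen alter other chloro or nitro groups on the same ring and stay modest or within the scatter. The change from compound 1 to compound 4 is therefore expected to give a step of about a 1.1-fold higher number from compound 1 to compound 4 (0.03 log units; within the scatter), with no confident direction. Compound 4 is estimated at 9000 nM, ranging from 4000 nM to 20000 nM.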

Compound 4, half-maximal inhibitory concentration: 21000 nM
For compound 4 the middle estimate is 2.3-fold (0.37 log units) below the measured one, outside the stated range (above it).
By their numbers in this assay, from the lowest: compounds 1, 3, 2 and 4 (each within the scatter of the next, the first and the last beyond it).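

Methylsulfanyl is not an interchangeable stand-in for chloro at this place on the ring: in this assay the swap weakens inhibition (a 2.5-fold higher number from compound 1 to compound 4 (0.40 log units; beyond the scatter)), a modest step. The change to 4-(methylsulfanyl)phenyl also separates from 2-chloro-5-nitrophenyl (a 2.3-fold higher number from compound 3 to compound 4 (0.36 log units; beyond the scatter)) but not from 2,3-dichlorophenyl (a 1.2-fold higher number from compound 2 to compound 4 (0.09 log units; within the scatter)). Nothing available explains why this swap moves the number. Still open, from the compounds shown here alone, is how methoxy, an amine or a carboxylic acid would read at this place, and whether a longer chain on the sulfur would shift the number further.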